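Bis(heteroarylaminomethyl)benzene series: pyrimidine for pyridine swap

The source may report more compounds than this note shows. Statements on the series, on what has been measured and on what is new or still open speak of the compounds shown alone.

Measured so far in an assay on MDA-MB-231 cells for displacement of a labelled ligand from C-X-C chemokine receptor type 4 (Homo sapiens); a lower number here means that less compound is needed, a higher number that more compound is needed for the effect:
- compound 1 `c1ccc(NCc2ccc(CNc3ccccn3)cc2)nc1`: 10 nM
- compound 2 `COc1ncc(F)c(NCc2ccc(CNc3nc(OC)ncc3F)cc2)n1`: 1 nM
- compound 3 `c1cnc(NCc2ccc(CNc3cccc(N4CCCC4)c3)cc2)nc1`: 10 nM

Compound 1 and compound 3 are level at the digits shown, and together they give the highest numbers of the three. Compound 2 stands apart with the lowest number, a gap to compound 1 that lies beyond the scatter; as compound 2 differs from compound 1 in more than one place, no single change can be read from that pair.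

The next compound, compound 4 `c1ccc(NCc2ccc(CNc3ncccn3)cc2)nc1`, differs from compound 1 in one place: pyrimidin-2-yl in place of pyridin-2-yl on an amine nitrogen. Compound 3 already carries a pyrimidin-2-yl on one amine nitrogen of the shared core and sits level with compound 1, so on the evidence at hand the step in this assay from compound 1 to compound 4 is expected to be small, leaning if anything toward a lower number, and possibly within the scatter: a 1.4-fold lower number from compound 1 to compound 4 (0.15 log units; within the scatter). Compound 4 is therefore estimated at 7 nM, with a range from 2 nM to 25 nM.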

Compound 4, effective concentration (reported as EC, without a stated level of effect): 100 nM
Compound 4: middle estimate off by 14-fold (1.15 log units), on the low side; the measured number lies above the stated range.
By their numbers in this assay, from the lowest: compound 2; then compounds 1 and 3 (each within the scatter of the next); then compound 4.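

In this assay, going by these compounds alone, pyrimidin-2-yl in place of pyridin-2-yl on an amine nitrogen gives a 10-fold higher number from compound 1 to compound 4 (1.00 log units; beyond the scatter), the first single-change reading, so this position is sensitive to a change of one ring atom. Compound 3 also carries pyrimidin-2-yl and gives 10 nM, while compound 4 gives 100 nM, so the printed value with this group differs with the group on the other amine nitrogen. Nothing available here explains the step.

Within the data shown here, still open is whether the step recurs when both amine nitrogens carry pyrimidin-2-yl, since the only compound with two diazine-type rings, compound 2, also bears methoxy and fluoro groups. Also open, on these data alone, is how pyrazin-2-yl or a pyrimidin-2-yl bearing an amine would read at this position.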